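Cyclobutyl in place of cyclopropyl on the shared core

The source may report more compounds than this note shows. Statements on the series, on what has been measured and on what is new or still open speak of the compounds shown alone.

In a physicochemical assay for solubility, in phosphate buffer, with a stated time of 18 h (on this read-out higher numbers stand for higher solubility and lower numbers for lower solubility), compound 1 (`CC(C)c1ncc2c(N)c(C#N)c(N)nc2n1`) gives > 1000000 nM as a limit of the assay, not a number. Within the data shown here, compound 2 (`N#Cc1c(N)nc2nc(C3CC3)ncc2c1N`) gives 23000 nM as the only actual number so far, so it cannot yet be ranked against another number. Compound 3 (`N#Cc1c(N)nc2nc(C3CCC3)ncc2c1N`) has cyclobutyl in place of cyclopropyl on an aromatic carbon. Among the measured compounds shown here, only one measured step bears on this change, and it is large: an at least 43-fold lower number from compound 1 to compound 2 (1.63 log units; beyond the scatter), with its size bounded by the limit of > 1000000 nM in this assay, at which 1 of the 2 values shown sits. Going by that single step, which is a different exchange and so offers a direction more than a size, a modest move to a lower number is expected in this assay, and it may stay within the scatter. The estimated move is a 1.9-fold lower number from compound 2 to compound 3 (0.28 log units; within the scatter) on this read-out. For compound 3 the estimate is 12000 nM as the expected value. The expected range runs from 4000 nM to 35000 nM.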

Compound 3, solubility: 217000 nM
Beside the measured number, compound 3's estimate is 18-fold (1.26 log units) below it; measured number above the stated range.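

In this assay, cyclobutyl in place of cyclopropyl on an aromatic carbon, at the place between two ring nitrogen atoms, gives a 9.4-fold higher number from compound 2 to compound 3 (0.97 log units; beyond the scatter), so this position responds to a single added ring carbon by more than the scatter and in the opposite direction to the earlier step. Cyclobutyl in place of isopropyl gives an at least 4.6-fold lower number from compound 1 to compound 3 (0.66 log units; beyond the scatter), which leaves compound 2, with cyclopropyl, holding the lowest number of the three. Compound 1 stands at a limit of the assay, not a number, so the step from it gives a bound and not a size: the limit of > 1000000 nM in this assay, at which 1 of the 3 values shown sits.

As far as these compounds go, whether the number keeps rising with a larger carbon ring such as cyclopentyl remains open. From the compounds shown here alone, how an amine or a carboxylic acid at this place would read in this assay also remains open.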